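The source may hold more compounds than are shown below. What is called first, only, known or untested is meant among the compounds shown, and "the series" means these compounds.

Measured compounds in an ADME assay (liver) for metabolic stability, with Liver microsome (Rattus norvegicus) as the target, using microsomes and NADPH, with a stated time of 30 min, tested at 1 uM; on this read-out lower numbers stand for slow clearance and higher numbers for fast clearance:
compound 1 `Nc1ccc(S(=O)(=O)N2CCN(c3ncc(C(O)(C(F)(F)F)C(F)(F)F)cc3C3CC3)CC2)cn1` gives 27 mL.min-1.g-1
compound 2 `COCC#Cc1cc(C(O)(C(F)(F)F)C(F)(F)F)cnc1N1CCN(S(=O)(=O)c2ccc(N)nc2)CC1` gives 399 mL.min-1.g-1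
compound 3 `CS(=O)(=O)Nc1cccc(-c2cc(C(O)(C(F)(F)F)C(F)(F)F)cnc2N2CCN(S(=O)(=O)c3ccc(N)nc3)CC2)c1` gives 81 mL.min-1.g-1

Compound 2 stands highest of the three; compound 3 is nearest, with the step of a 4.9-fold lower number from compound 2 to compound 3 (0.69 log units; beyond the scatter), and compound 1 is furthest, the step of a 15-fold higher number from compound 1 to compound 2 (1.17 log units; beyond the scatter) being the largest in the set. Compound 4 `Nc1ccc(S(=O)(=O)N2CCN(c3ncc(C(O)(C(F)(F)F)C(F)(F)F)cc3-c3ccncc3)CC2)cn1` carries the change (pyridin-4-yl in place of 3-methoxyprop-1-yn-1-yl on an aromatic carbon). The step that bears most directly on this is the replacement of the same 3-methoxyprop-1-yn-1-yl group by an aromatic ring, a 4.9-fold lower number from compound 2 to compound 3 (0.69 log units; beyond the scatter), a modest fall; a 3.0-fold higher number from compound 1 to compound 3 (0.48 log units; beyond the scatter) shows that such a ring still sits above the cyclopropyl of compound 1. A modest fall in this assay is therefore expected, estimated as a 4.4-fold lower number from compound 2 to compound 4 (0.65 log units; beyond the scatter). Compound 4 is expected to give 90 mL.min-1.g-1, with a range from 35 mL.min-1.g-1 to 230 mL.min-1.g-1.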

Compound 4, intrinsic clearance in microsomes: 31 mL.min-1.g-1
For compound 4 the middle estimate is 2.9-fold (0.46 log units) above the measured one; the measured number lies below the stated range.
By their numbers in this assay, from the lowest: compounds 1 and 4 (each within the scatter of the next); then compound 3; then compound 2.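

In this assay, an aromatic ring at this place need not raise the number over that of cyclopropyl: a 1.1-fold higher number from compound 1 to compound 4 (0.06 log units; within the scatter) leaves pyridin-4-yl and cyclopropyl not told apart. The choice of ring counts as well, with a 2.6-fold lower number from compound 3 to compound 4 (0.42 log units; beyond the scatter) separating two aromatic groups, while a 13-fold lower number from compound 2 to compound 4 (1.11 log units; beyond the scatter) makes pyridin-4-yl a large improvement on 3-methoxyprop-1-yn-1-yl. No measured property accounts for these steps. Open, going by these compounds, is whether unsubstituted phenyl, pyridin-3-yl or an aliphatic amine at this place would stay as low as compound 4 does.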